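Swapping a Phenoxy for a Dimethylamino on a Pyrazole Series

This account rests on a few compounds, and the source may have more. Where it says the series, first, only, none or still open, it means among the compounds named here.

Of the compounds shown here, three built around the same core have been tested in a functional assay on SN12C cells (Homo sapiens) for inhibition, read by sulforhodamine B assay, with a stated time of 48 h; a lower number here means that less compound is tolerated, a higher number that more compound is tolerated. Compound 1 `COc1cc(C)cc(-c2c(-c3ccnc(-c4ccc(C(C)=O)cc4)c3)cnn2CC#N)c1` reaches only the limit of the assay, giving > 100000 nM. Compound 2 `COc1cc(C)cc(-c2nn(CC#N)cc2-c2ccc(-c3cccc(C(C)=O)c3)nc2)c1` likewise stops at the limit, with > 100000 nM. Among the measured compounds shown here, compound 3 `Cc1cc(O)cc(-c2nn(CC#N)cc2-c2ccnc(-c3ccc(Oc4ccccc4)cc3)c2)c1` is different: in this assay compound 3 gives 9010 nM, which is the only actual number among the three results. For the measured compounds named here, compound 3 therefore stands alone as the one member of the set whose toxicity toward these kidney cancer cells could be pinned to a value, while the other two sit at the limit of > 100000 nM in this assay, at which 2 of the 3 values shown sit.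

The next compound, compound 4 `Cc1cc(O)cc(-c2nn(CC#N)cc2-c2ccnc(-c3ccc(N(C)C)cc3)c2)c1`, has not yet been tested. It differs from compound 3 in one place: dimethylamino in place of phenoxy on an aromatic carbon. Going by the values given here, no pair of measured compounds differs in only this way, so the size of this step is unknown. The expectation is a step toward a higher value, possibly beyond the usual scatter, since the smaller dimethylamino group replaces a larger aromatic one. Compound 4 is expected to give about 20000 nM in this assay, within a range from 5000 nM to 100000 nM, an expected step of a 2.2-fold higher number from compound 3 to compound 4 (0.35 log units; beyond the scatter).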

Compound 4, concentration lethal to 50% of the cells: > 100000 nM
Compound 4: no number, only a limit (the forecaster's own chance of this, stated with the estimate: 30%); middle value at least 5.0-fold (0.69 log units) away from the limit.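

Among the compounds shown here, this is the first pair in the set that differs in only one place, and it shows that the group on this aromatic carbon, para to a large group, matters in this assay: replacing phenoxy with dimethylamino gives an at least 11-fold higher number from compound 3 to compound 4 (1.04 log units; beyond the scatter). Compound 4 gives > 100000 nM, which is a limit of the assay and not a number. The step can therefore be read only as a minimum, and compound 3 remains the only compound here with an actual number, because compound 4 joins the others at the limit: the limit of > 100000 nM in this assay, at which 3 of the 4 values shown sit.

The change removes an aromatic ring and also replaces an oxygen link with a nitrogen, so the compounds shown cannot separate these two differences; a methoxy group, which keeps the oxygen without the ring, or a phenyl group, which keeps the ring without the oxygen, would begin to do so. As far as these compounds go, whether any other group on this carbon would give a lower number than compound 3 also remains open.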